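Amino for Nitro on an Inactive Sulfonyl Acetanilide

The source may report more compounds than this note shows. Statements on the series, on what has been measured and on what is new or still open speak of the compounds shown alone.

Compound 3 `COc1ccc(CS(=O)(=O)CC(=O)Nc2ccccc2)cc1[N+](=O)[O-]` was tested in a functional assay on MCF7 cells (Homo sapiens) for cytotoxicity, read by MTT assay, with a stated time of 72 h; on this read-out higher numbers stand for weaker inhibition of growth and lower numbers for stronger inhibition of growth. In this assay compound 3 reached only a limit, > 30000 nM, rather than a number. Compound 2 `COc1ccc(CS(=O)(=O)CC(=O)Nc2c(C)cc(C)cc2C)cc1[N+](=O)[O-]` likewise gave only a limit, > 30000 nM. Both sit at the limit of > 30000 nM in this assay, at which 2 of the 3 values shown sit, so the step that the two limits leave unreadable from compound 2 to compound 3 cannot be read. Compound 1 `COc1cc(OC)c(/C=C/S(=O)(=O)Cc2ccc(OC)c(N)c2)c(OC)c1`, built on a different core, reached a limit at the opposite end of the assay, < 10 nM; that value sits at the limit of < 10 nM in this assay, at which 1 of the 3 values shown sits. Within the data shown here, no step connects compound 1 to compound 3, and its value shows only that a compound carrying the amino and methoxy pairing can be potent in this setting.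

Compound 4 `COc1ccc(CS(=O)(=O)CC(=O)Nc2ccccc2)cc1N` differs from compound 3 by amino in place of nitro on an aromatic carbon. Among the measured compounds shown here, no measured step bears directly on this change, since both measured steps between compounds of the same core are hidden by limits. With compound 3 beyond the upper limit, the step of an at least 1.5-fold lower number from compound 3 to compound 4 (0.17 log units; that floor lies within the scatter) is expected to be modest at best, most likely within the scatter. Compound 4 is therefore estimated at 20000 nM, with a range from 3000 nM to 60000 nM, and a limit remains a likely outcome.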

Compound 4, concentration for 50% growth inhibition: > 30000 nM
Compound 4 was reported as a limit; the forecaster's own chance of this, stated with the estimate: 60%; middle value at least 1.5-fold (0.17 log units) from the limit.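

Compound 3 and compound 4 both end at the same upper limit in this assay, so the change from nitro to amino between them cannot be read as a step. The compounds shown leave open whether amino or nitro, or the group on the amide-type nitrogen, makes any difference to growth inhibition on the shared core.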